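Hydroxymethyl for (methylamino)methyl on the pyrrolidine chain

The source may hold more compounds than are shown below. What is called first, only, known or untested is meant among the compounds shown, and "the series" means these compounds.

In an assay on isolated protein for inhibition of DNA topoisomerase 1 (Homo sapiens), with a stated time of 15 min (on this read-out higher numbers stand for weaker inhibition and lower numbers for stronger inhibition), compound 1 `CNC[C@@H]1CCN(c2c(F)cc3c(=O)c(C(=O)O)cn(Cc4ccc(-c5ccccc5)cc4)c3c2OC)C1` gives 155000 nM, the lowest of the two numbers reported here, with compound 3 `CNC[C@@H]1CCN(c2cc3c(cc2F)c(=O)c(C(=O)O)cn3Cc2ccc(-c3ccccc3)cc2)C1` nearest at 168000 nM. The step of a 1.1-fold higher number from compound 1 to compound 3 (0.03 log units; within the scatter) is hydrogen in place of methoxy on an aromatic carbon. Compound 2 `COc1c(N2CC[C@@H](CN)C2)c(F)cc2c(=O)c(C(=O)O)cn(Cc3ccc(-n4cccn4)cc3)c12` returns only a limit, > 200000 nM, because of the limit of > 200000 nM in this assay, at which 1 of the 3 values shown sits, no number can be set for it. Compound 2 differs from compound 1 in more than one place, so its value is noted without a step.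

The unmeasured compound 4 `COc1c(N2CC[C@@H](CO)C2)c(F)cc2c(=O)c(C(=O)O)cn(Cc3ccc(-c4ccccc4)cc3)c12` differs from compound 1 by hydroxy in place of methylamino on a saturated chain carbon bound to a saturated ring carbon. Within the data shown here, none of the measured steps bears directly on this exchange: the single step on record, from compound 1 to compound 3, concerns the aromatic methoxy and sits within the scatter, and no pair in the set swaps the methylamino group alone. The expectation in this assay for compound 4 therefore rests on the level of compound 1, with the change a 1.4-fold higher number from compound 1 to compound 4 (0.15 log units; within the scatter) expected to stay within the scatter. For compound 4 the estimated value is 220000 nM, within an expected range from 90000 nM to 500000 nM, and a result reported only as a limit is quite possible.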

Compound 4, half-maximal inhibitory concentration: > 200000 nM
Compound 4 was reported as a limit (the forecaster's own chance of this, stated with the estimate: 45%); the middle value does not contradict the limit.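

Compound 4 gives > 200000 nM in this assay, and this is a limit of the assay, not a number. The exchange of (methylamino)methyl for hydroxymethyl on the pyrrolidine chain can therefore be read only as a floor, an at least 1.2-fold higher number from compound 1 to compound 4 (0.11 log units; that floor lies within the scatter): the change at this place brings no lower number, but whether it raises the number beyond the scatter cannot be told. Unlike the earlier step on the aromatic methoxy, which could be read as a full comparison, this first change on the chain meets the ceiling of the read-out, which now restricts what the series can show: the limit of > 200000 nM in this assay, at which 2 of the 4 values shown sit.

On these data alone, the size of the loss on removing methylamino remains open, as does whether any group on this chain would give a number clearly lower than that of compound 1. A dimethylamino group, a carboxylic acid or a longer aminoethyl chain at this place, each on the core of compound 1, would test whether the outcome depends on the group that ends the chain, provided the values fall below the limit.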